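Compound 3 to compound 4: methoxy in place of fluoro

The source may hold more compounds than are shown below. What is called first, only, known or untested is meant among the compounds shown, and "the series" means these compounds.

For the measured compounds named here, compound 3 `Cc1cccc(F)c1-c1nc(CN2CCC(C(=O)NCCCN3C[C@H](C)C[C@H](C)C3)CC2)c(C)o1` gives 234 10^-6 cm/s in a physicochemical assay for permeability, using PAMPA (a lower number here means that the compound crosses the layer more slowly, a higher number that the compound crosses the layer faster), and this is the only number so far. Compound 2 `Cc1oc(-c2c(Br)cccc2Br)nc1CN1CCC(C(=O)NCCCN2C[C@H](C)C[C@H](C)C2)CC1` reads < 1 10^-6 cm/s in this assay and that entry is a limit of the assay, not a number. Compound 1 `Cc1ccc(C)c(-c2nc(CN3CCC(C(=O)NCCCN4C[C@H](C)C[C@H](C)C4)CC3)c(C)o2)c1` stands at "not determined" (no result reported) and so offers no comparison.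

Compound 4 `COc1cccc(C)c1-c1nc(CN2CCC(C(=O)NCCCN3C[C@H](C)C[C@H](C)C3)CC2)c(C)o1` carries methoxy in place of fluoro on an aromatic carbon and keeps the methyl group, giving 2-methoxy-6-methylphenyl. Going by the values given here, the one measured step that bears on this is an at least 230-fold higher number from compound 2 to compound 3 (2.36 log units; beyond the scatter) and it is large, but it is counted from the limit of < 1 10^-6 cm/s in this assay, at which 1 of the 3 values shown sits, and it replaces both groups of 2,6-dibromophenyl at once. Among the compounds with values here, in compound 4 only one of the two groups changes, so a far smaller move is expected, slightly toward a lower number and not clearly beyond the scatter. The expected step is a 1.8-fold lower number from compound 3 to compound 4 (0.26 log units; within the scatter) and it remains an estimate. The range stays wide because an at least 230-fold higher number from compound 2 to compound 3 (2.36 log units; beyond the scatter) shows how far one change at this group has moved the read-out. In this assay the estimate for compound 4 is 130 10^-6 cm/s with an expected range of 25 10^-6 cm/s to 350 10^-6 cm/s for now.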

Compound 4, apparent permeability: 198 10^-6 cm/s
Estimate against measurement, compound 4: 1.5-fold (0.18 log units) below, and the stated range covers the measured number.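

In this assay, methoxy in place of fluoro, on an aromatic carbon ortho to a large group and meta to a methyl group, gives a 1.2-fold lower number from compound 3 to compound 4 (0.07 log units; within the scatter), so at this position one more heavy atom and one hydrogen-bond acceptor do not separate the two compounds. The change from 2,6-dibromophenyl to 2-methoxy-6-methylphenyl gives an at least 190-fold higher number from compound 2 to compound 4 (2.29 log units; beyond the scatter), which means that two different groups paired with the methyl group, fluoro and methoxy, now both stand on the same side of the large step seen from the dibromo compound. The size of that step is counted from a limit and not from a number, the entry of compound 2: the limit of < 1 10^-6 cm/s in this assay, at which 1 of the 4 values shown sits.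

Going by these compounds, it stays open whether the large step belongs to one bromo group or needs both, which a phenyl carrying one bromo and one methyl group would settle. On these data alone, it also stays open whether the tolerance seen for fluoro and methoxy extends to an amine or a carboxylic acid at the same position, since both groups compared here carry no net charge.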